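The source may report more compounds than this note shows. Statements on the series, on what has been measured and on what is new or still open speak of the compounds shown alone.

Measured so far in a physicochemical assay for permeability, using PAMPA; on this read-out higher numbers stand for higher permeability and lower numbers for lower permeability:
Compound 1, `Cc1cc(C)cc(NC(=O)Cn2ccc(=O)c3ccccc32)c1`, gives 450 nm/s.
Compound 2, `Cc1cc(C)cc(NC(=O)COc2ccnc3ccccc23)c1`, gives 460 nm/s.
Compound 3, `COc1ccc2nccc(OCC(=O)Nc3cc(C)cc(C)c3)c2c1`, gives 280 nm/s.

Compound 4, `COc1ccc2c(c1)c(=O)ccn2CC(=O)Nc1cc(C)cc(C)c1`, has not yet been measured in this assay. It is built from compound 1 by one change, (methoxy in place of hydrogen on an aromatic carbon). The same change, (methoxy in place of hydrogen on an aromatic carbon), links compound 2 to compound 3, and there it made a 1.6-fold lower number from compound 2 to compound 3 (0.22 log units; within the scatter). Compound 1 and compound 2 share the same atoms joined differently; the difference between the two cores is not broken down here, and their two numbers lie within the scatter of each other. Among the compounds with values here, on this basis the step from compound 1 to compound 4 is expected to be about a 1.5-fold lower number from compound 1 to compound 4 (0.18 log units; within the scatter), resting on the one measured example, a 1.6-fold lower number from compound 2 to compound 3 (0.22 log units; within the scatter). The estimated value for compound 4 is therefore 300 nm/s, expected to lie between 180 nm/s and 480 nm/s.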

Compound 4, apparent permeability: 190 nm/s
Beside the measured number, compound 4's estimate is 1.6-fold (0.20 log units) above it, within the range that was stated.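

With methoxy in place of hydrogen on an aromatic carbon, this assay shows a 2.4-fold lower number from compound 1 to compound 4 (0.37 log units; beyond the scatter) on one core and a 1.6-fold lower number from compound 2 to compound 3 (0.22 log units; within the scatter) on the other. Only the first step lies beyond the scatter, so a real drop is shown for the core of compound 1 alone, and two pairs cannot establish how well the size of this step carries from one core to another. Nothing given here explains either step.

Going by these compounds, it remains open whether ethoxy or an amine in place of the same hydrogen would give a similar step. On these data alone, it also remains open whether methoxy on another aromatic carbon would behave the same way.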